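Swapping one group on a sulfonamide nitrogen of compound 3

The source may report more compounds than this note shows. Statements on the series, on what has been measured and on what is new or still open speak of the compounds shown alone.

Compound 1 `CCc1ccc(N(C2COC2)S(=O)(=O)c2ccc3c(c2)C(O)CC(C2CCOCC2)O3)cc1`: 2.63
Compound 2 `CCc1ccc(N(C2CCC2)S(=O)(=O)c2ccc3c(c2)C(O)CC(C2CCOCC2)O3)cc1`: 3.69
Compound 3 `CCS(=O)(=O)c1ccc(CN(CC(C)C)S(=O)(=O)c2ccc3c(c2)C(O)CC(C2CCOCC2)O3)nc1`: 1.42

In a physicochemical assay for lipophilicity, at pH 7.4 (on this read-out higher numbers stand for higher lipophilicity and lower numbers for lower lipophilicity), compound 3 gives 1.42, the lowest of the three, and beyond the scatter from both others. Compound 4 `CCc1ccc(N(CC(C)C)S(=O)(=O)c2ccc3c(c2)C(O)CC(C2CCOCC2)O3)cc1` differs from compound 3 in one place, on a sulfonamide nitrogen: 4-ethylphenyl in place of (5-(ethylsulfonyl)pyridin-2-yl)methyl on a sulfonamide nitrogen. Among the measured compounds shown here, no measured step covers this exchange. The only one, a number 1.06 log units higher from compound 1 to compound 2 (beyond the scatter), is large, but it concerns cyclobutyl in place of oxetan-3-yl. Still, 4-ethylphenyl is also present in compound 1 at 2.63 and in compound 2 at 3.69. Compound 4 has no oxetan-3-yl, so compound 2 is the closer guide. A large rise is therefore expected, an estimated a number 2.38 log units higher from compound 3 to compound 4 (beyond the scatter). The expected value for compound 4 is 3.8, within an estimated range of 3.3 to 4.3.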

Compound 4, distribution coefficient: 4.12
For compound 4 the middle estimate is 0.32 log units below the measured one; the measured number falls inside the stated range.
By their numbers in this assay, from the lowest: compound 3; then compound 1; then compound 2; then compound 4.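

In this assay, among the compounds shown here, the groups on this sulfonamide nitrogen can shift the number a long way: 4-ethylphenyl in place of (5-(ethylsulfonyl)pyridin-2-yl)methyl gives a number 2.70 log units higher from compound 3 to compound 4 (beyond the scatter) as the largest step so far. With 4-ethylphenyl kept, the other group on that nitrogen also counts, since isobutyl in place of cyclobutyl gives a number 0.43 log units higher from compound 2 to compound 4 (beyond the scatter) as a modest step, while isobutyl in place of oxetan-3-yl gives a number 1.49 log units higher from compound 1 to compound 4 (beyond the scatter) as a large one.

Nothing shown explains the size of these steps. Also open, going by these compounds, is how a chain ending in an amine or a carboxylic acid would read on this nitrogen.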